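Hydroxamic acid series: ring methoxy addition, compound 3

A few compounds are considered here, and "the series" means these few. Any claim that something is new, unique, unknown or untested is made for them only; others in the source may bear on it.

Measured so far:
- compound 1 `COC(=O)c1ccc(CS(=O)(=O)Nc2ccc3c(c2)cc(C)c(=O)n3C)cc1`: 78%
- compound 2 `Cc1cc2cc(NS(=O)(=O)Cc3ccc(C(=O)NO)cc3)ccc2n(C)c1=O`: 27%

Within the data shown here, in a functional assay on HL-60 cells (Homo sapiens) for antiproliferative activity, tested at 100 uM (a higher number here means a stronger effect of the compound at the concentration tested, a lower number a weaker effect), compound 1 gives 78% and compound 2 gives 27%; the only step in hand is a number 51 percentage points lower from compound 1 to compound 2 (beyond the scatter). Compound 2 thus stands lowest of the two numbers, with compound 1 the nearest neighbour and beyond the scatter above it.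

Compound 3 `COc1cc(C(=O)NO)ccc1CS(=O)(=O)Nc1ccc2c(c1)cc(C)c(=O)n2C` differs from compound 2 by methoxy in place of hydrogen on an aromatic carbon. Among the measured compounds shown here, the one measured step concerns a change at the carbonyl carbon, not a substituent on the aromatic ring, so no measured step bears on this change, and the numbers give no direction for it. The expectation is therefore a step no larger than the scatter, a number 1 percentage points higher from compound 2 to compound 3 (within the scatter), the hydroxycarbamoyl group of compound 2 being kept. Compound 3 is expected to give about 28% in this assay, within 10% to 50%.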

Compound 3, a percentage reported as inhibition, at one concentration (the size of the read-out at that concentration, not a potency): 0%
For compound 3 the middle estimate is 28 percentage points above the measured one; the whole stated range lies above it.
By their numbers in this assay, from the lowest: compound 3; then compound 2; then compound 1.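

In this assay, a substituent on the aromatic ring now has a measured effect: methoxy in place of hydrogen, ortho to a large group and meta to a hydroxycarbamoyl group, gives a number 27 percentage points lower from compound 2 to compound 3 (beyond the scatter). This carbon therefore does not tolerate every change, and the step runs in the same direction as the earlier change at the carbonyl carbon, a number 51 percentage points lower from compound 1 to compound 2 (beyond the scatter). No measurement in hand accounts for this drop.

As far as these compounds go, whether the drop belongs to methoxy itself or would follow any group on this carbon remains open, and a fluorine atom or a hydroxy group there would separate the two. Also open, from the compounds shown here alone, is whether the same ring change would lower the number as much with a carboxylic acid in place of the hydroxycarbamoyl group.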